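Swapping the amine on the aryl amide: meta series

The source may report more compounds than this note shows. Statements on the series, on what has been measured and on what is new or still open speak of the compounds shown alone.

Measured so far:
Compound 1, `NS(=O)(=O)Oc1ccc2c(c1)CN(C(=O)c1ccc(N3CCCCC3)cc1)CC2`: 38.3%
Compound 2, `CCN(Cc1ccc(F)cc1)c1ccc(C(=O)N2CCc3ccc(OS(N)(=O)=O)cc3C2)cc1`: 91.2%
Compound 3, `CCN(Cc1ccc(F)cc1)c1cccc(C(=O)N2CCc3ccc(OS(N)(=O)=O)cc3C2)c1`: 66.5%

In an assay on HEK293 cells for inhibition of Steryl-sulfatase (Homo sapiens), tested at 1 uM (a higher number here means a stronger effect of the compound at the concentration tested, a lower number a weaker effect), compound 2 gives the highest number. Compound 3, built from the same atoms joined differently, gives a lower one; the difference between the two cores is not broken down here. Moving from compound 2 to compound 1 means (piperidin-1-yl in place of ethyl(4-fluorobenzyl)amino on an aromatic carbon), and this change gave a number 52.9 percentage points lower from compound 2 to compound 1 (beyond the scatter).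

Compound 4, `NS(=O)(=O)Oc1ccc2c(c1)CN(C(=O)c1cccc(N3CCCCC3)c1)CC2`, is still to be measured. Relative to compound 3 it carries piperidin-1-yl in place of ethyl(4-fluorobenzyl)amino on an aromatic carbon; the place differs, meta to a large group rather than para to a large group, so this is the same kind of change as from compound 2 to compound 1, not the same. Because compound 2 to compound 1 gave a number 52.9 percentage points lower from compound 2 to compound 1 (beyond the scatter), a step of similar size is expected, namely a number 46.5 percentage points lower from compound 3 to compound 4 (beyond the scatter). Compound 4 is therefore estimated at 20%, plausibly between 5% and 42%.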

Compound 4, a percentage reported as inhibition, at one concentration (the size of the read-out at that concentration, not a potency): 11.9%
Beside the measured number, compound 4's estimate is 8.1 percentage points above it, and the stated range covers the measured number.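

In this assay, piperidin-1-yl in place of ethyl(4-fluorobenzyl)amino gave a number 54.6 percentage points lower from compound 3 to compound 4 (beyond the scatter), and this step can be set against the same change on the other core: the same change on two cores in this assay, a number 52.9 percentage points lower (beyond the scatter) from compound 2 to compound 1 and a number 54.6 percentage points lower (beyond the scatter) from compound 3 to compound 4, 1.7 percentage points apart, within the scatter of two such steps. The drop therefore carried over from one core to the other at much the same size. Going by these compounds alone, this rests on only two pairs of compounds, and it shows neither why the number falls nor that the same would hold on a further core.

The compounds shown leave open which part of ethyl(4-fluorobenzyl)amino goes with the higher numbers. An amine carrying only the ethyl group or only the 4-fluorobenzyl group on its nitrogen would separate the two parts.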